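Amino in place of nitro: compound 2 to compound 3

The compounds below may be only part of what the source reports. "The series", "measured", "known", "first", "only" and "open" are said of these compounds alone.

For the measured compounds named here, in a functional assay on DU-145 cells (Homo sapiens) for cytotoxicity, read by trypan blue exclusion, with a stated time of 96 h (a higher number here means a weaker inhibitor, a lower number a stronger inhibitor), only two compounds have numbers so far. Compound 1 (`COc1ccc(CS(=O)(=O)/C=C/c2c(OC)cccc2OC)c(N)c1`) gives 750 nM and compound 2 (`COc1cc(OC)c(/C=C/S(=O)(=O)Cc2ccc(OC)cc2[N+](=O)[O-])c(OC)c1`) gives 20000 nM. Compound 2 holds the higher of the two numbers, beyond the scatter, and so is the weaker inhibitor of the pair. Compound 3 (`COc1ccc(CS(=O)(=O)/C=C/c2c(OC)cc(OC)cc2OC)c(N)c1`) is not yet measured. It differs from compound 2 by amino in place of nitro on an aromatic carbon, ortho to a large group and meta to a methoxy group (amino in place of nitro on an aromatic carbon). Going by the values given here, no measured pair shows this change on its own. Compound 1 also carries an amino group and gives 750 nM, which points to a lower number for compound 3 than for compound 2. The expected step, well beyond the scatter, is a 67-fold lower number from compound 2 to compound 3 (1.82 log units; beyond the scatter). The value expected for compound 3 is 300 nM, with an estimated range from 40 nM to 2000 nM.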

Compound 3, half-maximal inhibitory concentration: 25 nM
Compound 3: middle estimate off by 12-fold (1.08 log units), on the high side; the measured number lies below the stated range.
By their numbers in this assay, from the lowest: compound 3; then compound 1; then compound 2.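

In this assay the position ortho to a large group proves highly sensitive to what it carries: amino in place of nitro on this aromatic carbon gives an 800-fold lower number from compound 2 to compound 3 (2.90 log units; beyond the scatter) and is beyond the scatter. The amino group does not account for the whole result, since methoxy in place of hydrogen on an aromatic carbon elsewhere gives a 30-fold lower number from compound 1 to compound 3 (1.48 log units; beyond the scatter) with the amino group present in both compounds. Both steps are large and leave compound 3 as the strongest inhibitor of the three.

Going by these compounds, only nitro and amino are compared at this position, so it remains open how a hydroxyl group, a methylamino group or an acetamide would fare there. No measurement in hand explains the size of either step.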